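The source may report more compounds than this note shows. Statements on the series, on what has been measured and on what is new or still open speak of the compounds shown alone.

Measured so far in a physicochemical assay for metabolic stability, read by HPLC, in phosphate buffer, at pH 7.3; a higher number here means that the compound lasts longer, a lower number that the compound disappears faster

- Compound 1 (`CCCCCCCCCCCCCCCCOC(=O)Oc1ccc(COP(=O)(OCc2ccc(OC(=O)CC)cc2)OP(=O)(O)OP(=O)(O)OC[C@H]2C[C@@H](n3cc(C)c(=O)[nH]c3=O)C[C@@H]2O)cc1`) gives 74 h
- Compound 2 (`CCCCCCCCCCCCCCCCOC(=O)Oc1ccc(COP(=O)(OCc2ccc(OC(=O)CC)cc2)OP(=O)(O)OP(=O)(O)OC[C@@H]2O[C@H](n3cc(F)c(N)nc3=O)CS2)cc1`) gives 45 h

These two values lie within the usual scatter of each other, so on these numbers compound 2 cannot be told apart from compound 1. Still unmeasured is compound 3 (`CCCCCCCCCCCCCCCCOC(=O)Oc1ccc(COP(=O)(OCc2ccc(OC(=O)CCCC)cc2)OP(=O)(O)OP(=O)(O)OC[C@@H]2O[C@H](n3cc(F)c(N)nc3=O)CS2)cc1`), which differs from compound 2 in one place (ethyl in place of hydrogen on a saturated chain carbon, two bonds along the chain from a carbonyl carbon): ethyl in place of hydrogen on a saturated chain carbon, two bonds along the chain from a carbonyl carbon. The same difference also reads propanoyl to butylcarbonyl. Within the data shown here, no pair of measured compounds shows this change on its own, so no measured step can serve as a guide. In this assay no step beyond the scatter is expected, and the estimate starts from compound 2 (45 h). The expected step (a 1.1-fold higher number from compound 2 to compound 3 (0.05 log units; within the scatter)) is small. For compound 3 the estimated half-life, with its range, is 50 h (25 h to 100 h).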

Compound 3, half-life: 36 h
Compound 3: the middle estimate sits 1.4-fold (0.14 log units) above what was measured, and the stated range covers the measured number.
By their numbers in this assay, from the lowest: compounds 3, 2 and 1 (each within the scatter of the next, the first and the last beyond it).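

Among these compounds, this pair gives the first reading of a single change in this assay: the step, a 1.3-fold lower number from compound 2 to compound 3 (0.10 log units; within the scatter), comes from ethyl in place of hydrogen on a saturated chain carbon, two bonds along the chain from a carbonyl carbon. The same difference reads propanoyl to butylcarbonyl, and the step lies within the usual scatter, so on this pair the added ethyl leaves the half-life indistinguishable from that of compound 2. No measurement bearing on why the half-life responds in this way accompanies the result.

The compounds shown leave open whether a longer chain, an amine or a carboxylic acid in place of the ethyl would give a step beyond the scatter. They also leave open whether ethyl at this place would behave the same way on the core of compound 1.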